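The compounds below may be only part of what the source reports. "The series", "measured", "known", "first", "only" and "open" are said of these compounds alone.

Compound 2, whose structure is `N=C(NCCCc1c[nH]cn1)NCCC(c1ccccn1)c1ccccc1F`, was tested in a functional assay on ileum for antagonist activity at histamine H1 receptor (Cavia porcellus) (on this read-out higher numbers stand for weaker binding and lower numbers for tighter binding), and gives 437 nM. Among the two numbers measured so far this is the highest; the nearest is compound 1, with the structure `N=C(NCCCc1c[nH]cn1)NCCC(c1ccc(Br)cc1)c1ccccn1`, which in this assay gives 120 nM. Among the measured compounds shown here, the one measured step between these two compounds, a 3.6-fold higher number from compound 1 to compound 2 (0.56 log units; beyond the scatter), is the only guide available, and it concerns a different exchange of the aromatic ring on the same chain carbon.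

Compound 3, with the structure `N=C(NCCCc1c[nH]cn1)NCCC(c1ccccn1)c1ccccn1`, has not yet been measured in this assay. It differs from compound 2 in one place: pyridin-2-yl in place of 2-fluorophenyl on a saturated chain carbon bound to an aromatic carbon and a saturated chain carbon. For the measured compounds named here, no measured pair shows a ring of this kind entering at that position, so the direction of the step cannot be read off directly from the measured step from compound 1 to compound 2, which only shows that a change of this ring can shift the number by a modest amount.

For compound 3, therefore, a step of about a 1.1-fold lower number from compound 2 to compound 3 (0.04 log units; within the scatter) is expected, meaning the number should stay near that of compound 2. The estimate for compound 3 in this assay is 400 nM, with a range from 130 nM to 1200 nM.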

Compound 3, dissociation constant: 389 nM
Estimate against measurement, compound 3: 1.0-fold (0.01 log units) above; low and high end bracket the measured number.
By their numbers in this assay, from the lowest: compound 1; then compounds 3 and 2 (each within the scatter of the next).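

In this assay, among the compounds shown here, the step with pyridin-2-yl in place of 2-fluorophenyl, a 1.1-fold lower number from compound 2 to compound 3 (0.05 log units; within the scatter) on this occasion, is the first look at a ring with a hetero atom on this saturated chain carbon, and it leaves the two compounds indistinguishable even though pyridin-2-yl has 1 hydrogen-bond acceptor and 2-fluorophenyl has 0 hydrogen-bond acceptors. The other new step, a 3.2-fold higher number from compound 1 to compound 3 (0.51 log units; beyond the scatter) for pyridin-2-yl in place of 4-bromophenyl, shows that compound 1 stands apart from both other compounds, so among these three groups 4-bromophenyl alone goes with the tighter binding. No measured property of these groups is available to explain this pattern.

Compound 1 and compound 2 differ both in the halogen and in where it sits on the ring, so these compounds cannot show which of the two matters. A plain phenyl group, 4-fluorophenyl or 2-bromophenyl at this place would separate those two questions and would show whether a halogen on the ring is needed at all.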